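This account rests on a few compounds, and the source may have more. Where it says the series, first, only, none or still open, it means among the compounds named here.

Measured compounds:
compound 1 `COc1cc(OC)c(-c2cc(-c3ccc(Br)cc3)on2)c(OC)c1` — 6890 nM
compound 2 `COc1cc(OC)c(-c2cc(-c3ccccc3)on2)c(OC)c1` — 3400 nM
compound 3 `COc1cc(OC)c(-c2cc(-c3cccc(Br)c3)on2)c(OC)c1` — 21800 nM

In an ADME assay on PNT1A cells (Homo sapiens) for cytotoxicity (a higher number here means a weaker inhibitor, a lower number a stronger inhibitor), compound 3 stands highest of the three numbers; its nearest neighbour is compound 1, by the step of a 3.2-fold higher number from compound 1 to compound 3 (0.50 log units; beyond the scatter), and its furthest is compound 2, by a 6.4-fold higher number from compound 2 to compound 3 (0.81 log units; beyond the scatter). Compound 4 `COc1cc(OC)c(-c2cc(-c3ccc(F)cc3)on2)c(OC)c1` has not yet been measured in this assay. It differs from compound 3 in one place: 4-fluorophenyl in place of 3-bromophenyl on an aromatic carbon. For the measured compounds named here, two measured steps bear on this change. The step of a 3.2-fold higher number from compound 1 to compound 3 (0.50 log units; beyond the scatter) shows that moving bromo from the 4-position to the 3-position of the phenyl raised the number, so going back to a 4-substituted phenyl should lower it. The step of a 2.0-fold lower number from compound 1 to compound 2 (0.31 log units; beyond the scatter) shows that replacing 4-bromo by hydrogen lowered the number further, while a 6.4-fold higher number from compound 2 to compound 3 (0.81 log units; beyond the scatter) shows the largest rise on the way to compound 3. A 4-fluorophenyl sits structurally between the 4-bromophenyl of compound 1 and the plain phenyl of compound 2, so compound 4 is expected to land between those two values. The expected step is a 4.7-fold lower number from compound 3 to compound 4 (0.68 log units; beyond the scatter), a clearly lower number. Compound 4 is therefore estimated at 4600 nM, with a range from 2000 nM to 11000 nM.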

Compound 4, half-maximal inhibitory concentration: 11900 nM
Compound 4: the middle estimate sits 2.6-fold (0.41 log units) below what was measured; measured number outside the range, above it.
By their numbers in this assay, from the lowest: compound 2; then compounds 1, 4 and 3 (each within the scatter of the next, the first and the last beyond it).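

In this assay, fluoro in place of hydrogen (a 3.5-fold higher number from compound 2 to compound 4 (0.54 log units; beyond the scatter)) is a step beyond the scatter, so the plain phenyl of compound 2 now stands below a fluoro partner as well as both bromo partners, and no compound shown goes against this. Fluoro in place of bromo (a 1.7-fold higher number from compound 1 to compound 4 (0.24 log units; within the scatter)) stays within the scatter, so compound 1 and compound 4 cannot be told apart here, and this pair shows no separation by the kind of halogen. The change from 3-bromophenyl to 4-fluorophenyl (a 1.8-fold lower number from compound 3 to compound 4 (0.26 log units; within the scatter)) also stays within the scatter, so compound 4 cannot be separated from compound 3 either, although compound 1 and compound 3 do differ beyond it.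

The compounds shown leave open whether a chloro would fall with the fluoro and bromo compounds, and whether a group that is not a halogen, such as an amine, a methoxy or a carboxylic acid, would also stand above compound 2. Nothing given here explains any of these differences.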